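Fluoro in Place of tert-Butyl: An Expected Step

The source may report more compounds than this note shows. Statements on the series, on what has been measured and on what is new or still open speak of the compounds shown alone.

Of the compounds shown here, three that share one core have been measured in an ADME assay on the whole organism with Oryza sativa as the target, tested at 10 uM; a lower number here means a stronger effect, a higher number a weaker effect of the compound at the concentration tested. Compound 1 `CC(C)c1cccc(NC(=O)N[C@H](C)c2ccccc2)c1` gives 44%. Compound 2 `C[C@@H](NC(=O)Nc1ccccc1C(C)(C)C)c1ccccc1` gives 17%, and compound 3 `C[C@H](NC(=O)Nc1ccccc1C(C)(C)C)c1ccccc1` gives 100%. Compound 2 thus stands lowest of the three, the strongest effect at the concentration tested; compound 1 lies above it beyond the scatter, and compound 3 further still. Going by the values given here, the single step between compounds that differ in one place, a number 83 percentage points higher from compound 2 to compound 3 (beyond the scatter), rests on nothing but (the fact that compounds 2 and 3 differ only in the configuration as drawn).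

The step followed here leads from compound 2 to compound 4 `C[C@@H](NC(=O)Nc1ccccc1F)c1ccccc1`, not yet measured in this assay. The change is fluoro in place of tert-butyl on an aromatic carbon. Among the compounds with values here, no measured step bears on an exchange of this kind: the only step in hand is a change of configuration alone, and although it was large, it says nothing about a replacement of a group on the ring. The account therefore has no measured guide and the expectation is correspondingly broad. For compound 4 in this assay the expected value is 50%, with a range from 15% to 90%. This estimate would mean a step of a number 33 percentage points higher from compound 2 to compound 4 (beyond the scatter).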

Compound 4, a percentage reported as activity, at one concentration (the size of the read-out at that concentration, not a potency): 77%
The estimate for compound 4 lay 27 percentage points below the measured number, and the stated range covers the measured number.
By their numbers in this assay, from the lowest: compound 2; then compound 1; then compound 4; then compound 3.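

With the configuration of compound 2 kept, the exchange of tert-butyl for fluoro gives a number 60 percentage points higher from compound 2 to compound 4 (beyond the scatter) in this assay. The earlier compounds had shown a large step for a change of configuration alone; this result shows that the group on this aromatic carbon also matters, and that the low number of compound 2 at 17% does not carry over to fluoro, with compound 4 at 77%. What is known about these compounds does not bear on the reason for this step.

The compounds shown leave open how other groups on this aromatic carbon, such as methyl, chloro, methoxy, an amine or a carboxylic acid, would read in this assay, and so whether tert-butyl stands alone here or is one of several groups that keep the number low. Also open, from the compounds shown here alone, is whether the opposite configuration would give a step of similar size with fluoro in this place as it does with tert-butyl.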